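Acetamido for carboxy on the biaryl acid scaffold

The source may hold more compounds than are shown below. What is called first, only, known or untested is meant among the compounds shown, and "the series" means these compounds.

The measured compounds in an assay on COS-7 cells for inhibition of patatin-like phospholipase domain-containing protein 2 (Mus musculus), tested at 200 uM (on this read-out lower numbers stand for less inhibition and higher numbers for more inhibition at the one concentration tested (going by the name of the read-out)), are these. Compound 1 `CCOC(=O)c1cc(-c2ccc(OCC)cc2)ccn1` gives 72%. Compound 2 `CCOc1ccc(-c2cccc(C(=O)O)c2)cc1` gives 23%. Compound 3 `CCCCCCOC(=O)c1cccc(-c2ccc(OCC)cc2)c1` gives 48%.

Compound 2 stands lowest of the three numbers in this assay, with compound 3 nearest and compound 1 furthest away, both steps lying beyond the scatter. Compound 4 `CCOc1ccc(-c2cccc(NC(C)=O)c2)cc1` differs from compound 2 in one place: acetamido in place of carboxy on an aromatic carbon.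

Among the compounds with values here, only one measured step touches the same group: a number 25 percentage points higher from compound 2 to compound 3 (beyond the scatter). That change, hexyl in place of hydrogen on an oxygen next to a carbonyl group, is not the same as the move to acetamido, but it shows that altering the carboxy group of compound 2 raised the number in this assay. Compound 1, which also carries an ester rather than a free acid, gives the highest number of the three. Within the data shown here, no step in the data describes acetamido in place of carboxy, so the direction rests on the observation that both measured carboxy derivatives lie above the acid.

Compound 4 is therefore expected to show a modest rise, a number 17 percentage points higher from compound 2 to compound 4 (beyond the scatter), against compound 2. The estimate for compound 4 in this assay is 40%, within a range from 20% to 60%.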

Compound 4, a percentage reported as inhibition, at one concentration (the size of the read-out at that concentration, not a potency): 52%
Compound 4: the middle estimate sits 12 percentage points below what was measured; the measured number falls inside the stated range.
By their numbers in this assay, from the lowest: compound 2; then compounds 3 and 4 (each within the scatter of the next); then compound 1.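

In this assay, acetamido in place of carboxy on this aromatic carbon gives a number 29 percentage points higher from compound 2 to compound 4 (beyond the scatter), so a rise over the acid of compound 2 does not depend on keeping an ester, the change behind a number 25 percentage points higher from compound 2 to compound 3 (beyond the scatter). The computed counts of hydrogen-bond donors and acceptors are the same for carboxy and acetamido, so those counts do not follow the step, and compound 3 at 48% and compound 4 at 52% lie within the scatter of each other although one carries a hexyl ester and the other an acetamido group. No supporting data bear on why the number rises with this change.

From the compounds shown here alone, whether a primary amine, a sulfonamide or a longer acyl chain such as butyramido on this aromatic carbon would read like compound 4 or fall back towards compound 2 remains open. The read-out also comes from a single concentration, so these compounds give a size of inhibition at that concentration and leave their potencies open.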